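Returning from 1-phenylethyl to a substituted benzyl

A few compounds are considered here, and "the series" means these few. Any claim that something is new, unique, unknown or untested is made for them only; others in the source may bear on it.

Among the compounds with values here, compound 3 `Cc1noc(-c2nc(C)c3c(c2N)C(=O)N(C(C)c2ccccc2)C3=O)n1` carries a 1-phenylethyl group on the amide-type nitrogen in a ring, and in a physicochemical assay for solubility, using the shake flask method, in simulated intestinal fluid, measured as kinetic solubility, with a stated time of 2 h, at 25 degrees C, at pH 6.5 (a lower number here means a less soluble compound, a higher number a more soluble compound), compound 3 gives 10900 nM, the only true number among the three measured values. Compound 1 `Cc1noc(-c2nc(C)c3c(c2N)C(=O)N(Cc2ccc(Cl)cc2)C3=O)n1` gives < 5000 nM in this assay, which is a limit of the assay and not a number. Compound 2 `Cc1noc(-c2nc(C)c3c(c2N)C(=O)N(Cc2cccc(F)c2)C3=O)n1` likewise gives < 5000 nM, again a limit. Both sit at the limit of < 5000 nM in this assay, at which 2 of the 3 values shown sit. The step of an at least 2.1-fold higher number from compound 1 to compound 3 (0.33 log units; beyond the scatter) and the step of an at least 2.1-fold higher number from compound 2 to compound 3 (0.33 log units; beyond the scatter) point the same way, while a step that the two limits leave unreadable from compound 1 to compound 2 cannot be read. Compound 4 `Cc1noc(-c2nc(C)c3c(c2N)C(=O)N(Cc2ccc(C#N)cc2)C3=O)n1` differs from compound 3 by 4-cyanobenzyl in place of 1-phenylethyl on an amide-type nitrogen in a ring. This change runs against the two readable steps, as it replaces 1-phenylethyl with 4-cyanobenzyl. Compound 4 is therefore expected to give a lower number than compound 3, with the estimated step of a 2.2-fold lower number from compound 3 to compound 4 (0.34 log units; beyond the scatter). The estimate for compound 4 is 5000 nM, with an expected range from 2000 nM to 14000 nM.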

Compound 4, solubility: < 5000 nM
Compound 4 gave a limit, no number; the forecaster's own chance of this, stated with the estimate: 50%; the middle value lies on the limit itself.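

In this assay, the change to 4-cyanobenzyl gives an at least 2.1-fold lower number from compound 3 to compound 4 (0.33 log units; beyond the scatter), so the earlier contrast with 1-phenylethyl on this amide-type nitrogen in a ring now extends to a benzyl group bearing a nitrile. Compound 4 gives < 5000 nM, which is a limit and not a number. The steps among compound 1, compound 2 and compound 4 cannot be read, and among the values shown, only compound 3 stands clear of the limit: the limit of < 5000 nM in this assay, at which 3 of the 4 values shown sit.

As far as these compounds go, how the chloro, fluoro and cyano compounds rank among themselves remains open. From the compounds shown here alone, it is also open whether the difference follows the methyl on the chain carbon of 1-phenylethyl or the ring substituents, and how a plain benzyl or a benzyl bearing a morpholine would read in this assay.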